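Notes on amine-nitrogen substituents in a shared core

The compounds below may be only part of what the source reports. "The series", "measured", "known", "first", "only" and "open" are said of these compounds alone.

Measured compounds:
compound 1 `Cc1nc(S(C)(=O)=O)ccc1Oc1ncnc(OC2CCN(C(=O)OC(C)(C)C#N)CC2)c1F`: 92.9 nM
compound 2 `Cc1nc(S(C)(=O)=O)ccc1Oc1ncnc(OC2CCN(C(=S)OC(C)C)CC2)c1F`: 69.9 nM

Both were measured in a functional assay on isolated protein for inhibition of Glucose-dependent insulinotropic receptor (Homo sapiens), read by HTRF and cAMP accumulation; a higher number here means that more compound is needed for the effect, a lower number that less compound is needed. The two values lie within the scatter of each other, with a 1.3-fold lower number from compound 1 to compound 2 (0.12 log units; within the scatter), so compound 2 and compound 1 are not separated by this assay; compound 2 is simply the second of two points on the same core, both differing only in the group on the amine nitrogen in the ring.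

Compound 3 `Cc1nc(S(C)(=O)=O)ccc1Oc1ncnc(OC2CCN(C(=O)C3(F)CCC3)CC2)c1F` is not yet measured. It differs from compound 2 as follows: a group of 7 heavy atoms (5 carbon, 1 oxygen, 1 fluorine; one four-membered non-aromatic ring of carbon only) in place of a group of 6 heavy atoms (4 carbon, 1 oxygen, 1 sulfur; no ring), on an amine nitrogen in a ring. Among the compounds with values here, the only step available, from compound 1 to compound 2, changed the same position and was within the scatter; it is the sole guide to this step, and it gives no reason to expect a shift beyond the scatter in this assay when the group on that nitrogen is exchanged again.

For compound 3 the expected value in this assay is therefore 75 nM, with a range of 30 nM to 190 nM, which means an expected step of a 1.1-fold higher number from compound 2 to compound 3 (0.03 log units; within the scatter).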

Compound 3, half-maximal effective concentration: 24.7 nM
Compound 3: middle estimate off by 3.0-fold (0.48 log units), on the high side; the whole stated range lies above it.
By their numbers in this assay, from the lowest: compound 3; then compounds 2 and 1 (each within the scatter of the next).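

In this assay the group on the amine nitrogen in a ring can move the number beyond the scatter: the exchange gives a 2.8-fold lower number from compound 2 to compound 3 (0.45 log units; beyond the scatter) and the change on the carbonyl carbon gives a 3.8-fold lower number from compound 1 to compound 3 (0.58 log units; beyond the scatter) while the earlier pair of compounds stayed within the scatter of each other. Within the data shown here, both new steps are modest, and of the three groups only the one in compound 3 holds a four-membered non-aromatic ring of carbon only and a fluorine, so the ring and the fluorine cannot be told apart in their share of the change. Nothing at hand bears on why this exchange lowers the number.

As far as these compounds go, it remains open how the number would respond to hydrogen or a methyl group in place of the fluorine, or to a three-membered or five-membered carbon ring in place of the four-membered one. Also open, from the compounds shown here alone, is whether a carbonyl bearing an open chain such as tert-butyl would give a similar step, or whether the ring is needed at all.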